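A Methyl Added to the Anilide Ring of Compound 1

The compounds below may be only part of what the source reports. "The series", "measured", "known", "first", "only" and "open" are said of these compounds alone.

The measured compounds and their numbers:
Compound 1 `COc1cc2c(Nc3nc4ccc(C(=O)Nc5c(C)cccc5C)cc4s3)ncnc2cc1OCCCN1CCCC1` gives 15700 nM in a functional assay on K562 cells (Homo sapiens) for cytotoxicity, read by WST assay, with a stated time of 72 h; a lower number here means a stronger inhibitor, a higher number a weaker inhibitor.
Compound 2 `CCN(CC)CCCOc1cc2ncnc(Nc3nc4ccc(C(=O)Nc5c(C)cccc5C)cc4s3)c2cc1OC` gives 28400 nM in this assay.
Compound 3 `COc1cc2c(Nc3nc4ccc(C(=O)Nc5c(C)cccc5C)cc4s3)ncnc2cc1OCCCN1CCC(C)CC1` gives 15800 nM in this assay.

All three share the core of compound 1 and differ only in the amine at the end of the chain on the aromatic oxygen. The steps between them are small: a 1.8-fold higher number from compound 1 to compound 2 (0.26 log units; within the scatter), a 1.0-fold higher number from compound 1 to compound 3 (0.00 log units; within the scatter) and a 1.8-fold lower number from compound 2 to compound 3 (0.25 log units; within the scatter). Compound 1 therefore stands among three numbers that sit within the scatter of one another, and none of the three can be told apart.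

Compound 4 `COc1cc2c(Nc3nc4ccc(C(=O)Nc5c(C)cc(C)cc5C)cc4s3)ncnc2cc1OCCCN1CCCC1` takes a different route. Compared with compound 1 the change is methyl in place of hydrogen on an aromatic carbon. Going by the values given here, none of the measured steps bears on this change, since every one of them alters the amine on the chain and leaves the anilide ring untouched. With nothing to point either way, the expectation for compound 4 is a number close to that of compound 1, with a wider range than usual to allow for the untested position.

Compound 4 is thus expected to give about 15000 nM, within 6000 nM to 40000 nM. This estimate means a step, a 1.0-fold lower number from compound 1 to compound 4 (0.02 log units; within the scatter), that is expected to remain within the scatter.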

Compound 4, half-maximal inhibitory concentration: 4300 nM
For compound 4 the middle estimate is 3.5-fold (0.54 log units) above the measured one, outside the stated range (below it).
By their numbers in this assay, from the lowest: compound 4; then compounds 1, 3 and 2 (each within the scatter of the next).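

On the anilide ring, going from 2,6-dimethylphenyl to 2,4,6-trimethylphenyl in this assay gives a 3.7-fold lower number from compound 1 to compound 4 (0.56 log units; beyond the scatter), so a single added methyl at this position, para to the large group, can be told apart from the scatter. The three amines on the chain gave steps that all stayed within the scatter, which makes this the only change among the compounds shown that clearly moves the number, and it does so from a part of the molecule that the amine steps left untouched. No measurement here explains why this methyl lowers the number. 

From the compounds shown here alone, whether the methyl itself matters, or whether another group at the same position would do the same, stays open, for example a chlorine, a methoxy or an ethyl group. Going by these compounds, it is also open whether the 2,4,6-trimethylphenyl group would lower the number to a similar extent with diethylamino or 4-methylpiperidin-1-yl at the end of the chain in place of pyrrolidin-1-yl.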